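Notes on a spiro-hydantoin series at the cholesterol transporter

The source may report more compounds than this note shows. Statements on the series, on what has been measured and on what is new or still open speak of the compounds shown alone.

Of the compounds shown here, three of the shared core have been measured in an assay on HEK293 cells for displacement of a labelled ligand from NPC1-like intracellular cholesterol transporter 1 (Homo sapiens); on this read-out higher numbers stand for weaker inhibition and lower numbers for stronger inhibition. Compound 1 `CC(C)(C)OC(=O)NCC1CCCN(C(=O)CN2CN(c3ccccc3)C3(CCN(C(=O)c4ccc(C5CCCCC5)cc4)CC3)C2=O)C1` gives 3800 nM. Compound 3 `CS(=O)(=O)N1CCN(C(=O)CN2CN(c3ccccc3)C3(CCN(C(=O)c4ccc(C5CCCCC5)cc4)CC3)C2=O)CC1` gives 6300 nM. Compound 2 `CC(C)(C)OC(=O)NCCCCCNC(=O)CN1CN(c2ccccc2)C2(CCN(C(=O)c3ccc(C(C)(C)C)cc3)CC2)C1=O` gives 13700 nM, the highest of the three numbers: the gap to compound 3 and the wider gap to compound 1 both lie beyond the scatter, so compound 2 is the weakest inhibitor of the set on this read-out. Among the measured compounds shown here, the three differ from one another in more than one place, so no single-point step between them can be drawn.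

Compound 4 `CC(C)(C)c1ccc(C(=O)N2CCC3(CC2)C(=O)N(CC(=O)NCN)CN3c2ccccc2)cc1` has not been measured. It is derived from compound 2 by one change: amino in place of 4-((tert-butoxycarbonyl)amino)butyl on a saturated chain carbon bound to an amide-type nitrogen. For the measured compounds named here, nothing among the measured compounds isolates this change, so the size of the step in this assay is open. With the two other measured compounds standing at lower numbers than compound 2 in this assay, compound 4 is expected to give a somewhat lower number, with the step of a 1.5-fold lower number from compound 2 to compound 4 (0.18 log units; within the scatter) estimated to fall near the edge of the scatter. Compound 4 is thus expected at 9000 nM, within a range of 3000 nM to 30000 nM.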

Compound 4, half-maximal inhibitory concentration: 26500 nM
Estimate against measurement, compound 4: 2.9-fold (0.47 log units) below; the range from low to high includes it.
By their numbers in this assay, from the lowest: compounds 1 and 3 (each within the scatter of the next); then compounds 2 and 4 (each within the scatter of the next).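

In this assay, the place on a saturated chain carbon bound to an amide-type nitrogen gives its first single-change reading: amino in place of 4-((tert-butoxycarbonyl)amino)butyl is a 1.9-fold higher number from compound 2 to compound 4 (0.29 log units; within the scatter). Losing a group of 12 heavy atoms, with its carbamate and chain, therefore leaves the two compounds inseparable on this read-out, and the earlier compounds, which differ in more than one place, could not show this. No measurement on hand explains this result.

This one change removes the chain and the tert-butoxycarbonyl group together, so their separate contributions cannot be read. As far as these compounds go, whether a hydroxyl, a carboxylic acid or a shorter chain ending in a free amine at this place would move the number beyond the scatter remains open.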